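Dimethylamino for methyl on the arylidene ring

The compounds below may be only part of what the source reports. "The series", "measured", "known", "first", "only" and "open" are said of these compounds alone.

Measured so far:
compound 1, `Cc1ccc(/C=C2\SC(=O)N(Cc3ccc(C)cc3)C2=O)cc1`: 16.3%
compound 2, `COc1ccc(/C=C2\SC(=O)N(Cc3ccc(C)cc3)C2=O)c(OC)c1`: 21.8%

The two compounds share one core and differ only in the substitution of the arylidene ring. In a functional assay on the whole organism (plasma) with Mus musculus as the target, with a stated time of 15 days, at a dose of 10 mg/kg by the oral route (a higher number here means a stronger effect of the compound at the dose given, a lower number a weaker effect), compound 1 gives 16.3%, the lowest of the two numbers, and compound 2 gives 21.8%; the two values lie within the scatter of each other, so neither can be called the more active. For the measured compounds named here, no step between measured compounds is recorded here, and nothing is known about what a change at this position does to the read-out.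

Compound 3, `Cc1ccc(CN2C(=O)S/C(=C\c3ccc(N(C)C)cc3)C2=O)cc1`, is not yet measured. It differs from compound 1 in one place: dimethylamino in place of methyl on an aromatic carbon. Going by the values given here, with no measured step to lean on, the account can only note that the two measured numbers sit close together and that the change is a small one on the same ring position. The step expected for a number 3.7 percentage points higher from compound 1 to compound 3 (within the scatter) is therefore one of modest size, without a clear direction, and may well fall within the scatter. For compound 3 the estimated activity is 20%, with a range from 5% to 40%.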

Compound 3, a percentage reported as activity, at one dose (the size of the read-out at that dose, not a potency): 14.9%
The estimate for compound 3 lay 5.1 percentage points above the measured number, and the stated range covers the measured number.
By their numbers in this assay, from the lowest: compounds 3, 1 and 2 (each within the scatter of the next).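

For the compounds shown here, the pair of compound 1 and compound 3 gives the first recorded step at this position: in this assay, dimethylamino in place of methyl on an aromatic carbon, para to a large group, gives a number 1.4 percentage points lower from compound 1 to compound 3 (within the scatter). This exchange brings in nitrogen and a hydrogen-bond acceptor, yet the read-out at this single dose does not separate the two compounds, so this one change on the arylidene ring shows no measurable effect on the number. No measurement at hand bears on why the read-out stays within the scatter across this exchange, and no explanation can be offered from these compounds.

From the compounds shown here alone, what remains open is whether any group at this place can move the number beyond the scatter, for example a carboxylic acid, a morpholine ring or a longer alkoxy chain, since one step between two groups says little about the position as a whole. Going by these compounds, it is also open whether the methyl on the benzyl ring attached to the ring nitrogen matters more, as replacing it with a chlorine or an amine would be a separate single change on the core of compound 1.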